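A few compounds are considered here, and "the series" means these few. Any claim that something is new, unique, unknown or untested is made for them only; others in the source may bear on it.

Measured series, all in a functional assay on the whole organism (brain) with Mus musculus as the target; a lower number here means that less compound is needed, a higher number that more compound is needed for the effect:
- compound 1 `O=[N+]([O-])c1ccc(CSCc2c[nH]cn2)cc1`: > 10 mg/kg (a limit, not a number)
- compound 2 `CC(=O)c1ccc(OCCc2c[nH]cn2)cc1`: 3.2 mg/kg
- compound 3 `O=C(c1ccccc1)c1ccc(OCCc2c[nH]cn2)cc1`: 2.6 mg/kg

Compound 2 has one numeric neighbour in this assay, and the comparison is a 1.2-fold lower number from compound 2 to compound 3 (0.09 log units; within the scatter). Going by the values given here, compound 1 stands at > 10 mg/kg, which is a limit of the assay, and no measured step starts from it.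

The next structure is compound 4 `CCc1ccc(OCCc2c[nH]cn2)cc1`, which carries ethyl in place of acetyl on an aromatic carbon. The carbonyl leaves with the acetyl group.

Among the compounds with values here, only one measured step bears on this change, namely a 1.2-fold lower number from compound 2 to compound 3 (0.09 log units; within the scatter). That step alters the group on the carbonyl carbon and keeps the carbonyl itself, so it is indirect evidence at best. Within the data shown here, no measured step removes the carbonyl. The series therefore gives no ground for expecting a change of any particular direction, although the missing test calls for a wide range.

The expected outcome is a 1.1-fold higher number from compound 2 to compound 4 (0.04 log units; within the scatter), so no shift beyond the scatter is anticipated. The estimate for compound 4 is 3.5 mg/kg. The expected range for compound 4 runs from 1.2 mg/kg to 10 mg/kg.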

Compound 4, dose for half-maximal effect: > 10 mg/kg
Compound 4: only a limit was reported (the forecaster's own chance of this, stated with the estimate: 15%); middle value at least 2.8-fold (0.45 log units) from the limit.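

In this assay, going by these compounds alone, ethyl in place of acetyl on an aromatic carbon, para to a group of 8 heavy atoms, gives the first change at this position that lies beyond the scatter: an at least 3.1-fold higher number from compound 2 to compound 4 (0.49 log units; beyond the scatter). The earlier step, a 1.2-fold lower number from compound 2 to compound 3 (0.09 log units; within the scatter), altered the group on the carbonyl carbon and kept the carbonyl, so the two steps together show that a swap of methyl for phenyl on the carbonyl carbon leaves the number within the scatter, while the change that takes the carbonyl away with the acetyl group does not. Compound 4 stands at > 10 mg/kg, which is a limit and not a number, so the step gives only a minimum size: the limit of > 10 mg/kg in this assay, at which 2 of the 4 values shown sit.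

The compounds shown leave open whether the carbonyl itself is what matters or whether another group on this aromatic carbon, such as a nitrile, a methoxy or a hydroxyethyl group, would keep the number near that of compound 2. Compound 1 differs from compound 2 in more than one place and adds nothing on this question.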